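This account rests on a few compounds, and the source may have more. Where it says the series, first, only, none or still open, it means among the compounds named here.

Notes on the series. Within the data shown here, all three compounds measured so far share one core and differ only in the group on the outer ring nitrogen. Compound 1 `Cn1c(=O)[nH]c2c(cnn2-c2ccccc2[N+](=O)[O-])c1=N` carries a nitro-substituted phenyl group; in an assay on membranes from brain for binding affinity to adenosine receptor A1 (Rattus norvegicus), read by radioligand binding, tested at 20 uM (a lower number here means less inhibition, a higher number more inhibition at the concentration tested (going by the name of the read-out)), compound 1 gives 5%. Compound 2 `Cn1c(=O)[nH]c2c(cnn2C)c1=N` carries a methyl group in that place, and in this assay compound 2 gives 6%. Compound 3 `Cn1c(=O)[nH]c2c(cnn2-c2ccc([N+](=O)[O-])cc2)c1=N` carries the nitro group on a different carbon of the phenyl ring, and in this assay compound 3 gives 5%. Compound 1 sits level with compound 3 at the digits recorded, and the gap to compound 2 also lies within the scatter, so the three numbers cannot be told apart; none of the substituents tried so far moves the read-out away from the low end of the scale.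

Compound 4 `Cn1c(=O)[nH]c2c(cnn2-c2ccccc2Cl)c1=N` is the next member, not yet measured. Relative to compound 1 it differs as follows: chloro in place of nitro on an aromatic carbon. Among the measured compounds shown here, no measured pair shows this kind of exchange, so there is no step to lean on; the only guide is that the whole series, compound 1 through compound 3, stays flat within the scatter. The expected step from compound 1 to compound 4 in this assay is therefore a number 1 percentage points higher from compound 1 to compound 4 (within the scatter), that is none beyond the scatter. For compound 4 in this assay the estimate is 6%, with a range from 0% to 18%.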

Compound 4, a percentage reported as inhibition, at one concentration (the size of the read-out at that concentration, not a potency): 7%
Compound 4: the middle estimate sits 1 percentage points below what was measured, within the range that was stated.
By their numbers in this assay, from the lowest: compounds 1, 3, 2 and 4 (each within the scatter of the next).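

Chloro in place of nitro on this aromatic carbon, ortho to a large group, gives in this assay a number 2 percentage points higher from compound 1 to compound 4 (within the scatter). Among these compounds, this is the first step that can be read for a single exchange, and it shows that this place on the phenyl ring takes the swap from nitro, with 3 heavy atoms and 2 hydrogen-bond acceptors, to chloro, with 1 heavy atom and no hydrogen-bond acceptors, without a step beyond the scatter. No measurement at hand offers an explanation for the read-out staying flat across this exchange.

Still open, on these data alone, is whether an amine or a carboxylic acid on this aromatic carbon would give a read-out that stands apart from compound 1 and compound 4, whose numbers lie within the scatter of each other. Also open, as far as these compounds go, is whether a longer chain on the outer ring nitrogen, in place of the phenyl group, or a change to the shared core would lift the read-out in this assay off the low end of the scale.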